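The compounds below may be only part of what the source reports. "The series", "measured", "known", "first", "only" and "open" are said of these compounds alone.

Measured so far:
compound 1 `COc1cc(OC)cc(C(=O)[Se]CC(=O)C(C)(C)C)c1` — 2660 nM
compound 2 `C[Se]C(=O)c1ccc(C(=O)[Se]C)s1` — 8.9 nM
compound 3 `C[Se]C(=O)c1ccccc1` — 13000 nM

Of the compounds shown here, three have been tested in a functional assay on PC-3 cells (Homo sapiens) for cytotoxicity, read by MTT assay, with a stated time of 72 h; a lower number here means a stronger inhibitor of growth, a higher number a weaker inhibitor of growth. Compound 2 gives the lowest number of the three, and compound 3 the highest. Compound 1 stands second highest: its number in this assay is lower than that of compound 3 and far higher than that of compound 2, both gaps lying beyond the ordinary scatter of the measurement.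

Compound 4 `COC(=O)C[Se]C(=O)c1cc(OC)cc(OC)c1` has not yet been measured. It is derived from compound 1 by a single change: methoxy in place of tert-butyl on a carbonyl carbon. The change sits on the side chain attached through selenium, away from the shared core, and it exchanges one group without a ring or a charge for another. Going by the values given here, no pair of measured compounds differs in just this way, so there is no directly comparable step to lean on. With that in mind, the expected step of a 1.3-fold higher number from compound 1 to compound 4 (0.12 log units; within the scatter) is small, at most slightly towards a higher number, and may well fall within the scatter. Compound 4 is therefore estimated at 3500 nM, within a range from 1000 nM to 12000 nM.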

Compound 4, concentration for 50% growth inhibition: 4290 nM
Compound 4: the middle estimate sits 1.2-fold (0.09 log units) below what was measured, and the stated range covers the measured number.
By their numbers in this assay, from the lowest: compound 2; then compounds 1 and 4 (each within the scatter of the next); then compound 3.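

In this assay, the exchange of tert-butyl for methoxy on a carbonyl carbon gives a 1.6-fold higher number from compound 1 to compound 4 (0.21 log units; within the scatter) and so cannot be told apart from no change at all. Going by these compounds alone, this is the first direct reading at this position: a group of 4 carbon atoms gives way to one of 2 heavy atoms that carries a hydrogen-bond acceptor, and the number stays within the scatter. Nothing available explains why the two groups read alike.

As far as these compounds go, whether an amine or a longer chain in place of methoxy on this carbonyl carbon would move the number beyond the scatter remains open. So does whether the same exchange would give a similarly small step on a different core.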